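Hydroxymethyl in place of 1-hydroxy-1-methylethyl on the amide

The source may report more compounds than this note shows. Statements on the series, on what has been measured and on what is new or still open speak of the compounds shown alone.

Measured compounds:
- Compound 1 `CCCC(=O)Nc1cc(Oc2ccc(Nc3nccc4[nH]cc(-c5ccc(F)cc5)c(=O)c34)cc2F)ccn1` gives 23.5% in a functional assay on HT-29 cells (Homo sapiens) for antiproliferative activity, read by MTT assay, with a stated time of 72 h, tested at 10 uM; a higher number here means more inhibition at the concentration tested (going by the name of the read-out), a lower number less inhibition.
- Compound 2 `CCCCC(=O)Nc1cc(Oc2ccc(Nc3nccc4[nH]cc(-c5ccc(F)cc5)c(=O)c34)cc2F)ccn1` gives -42.2% in this assay.
- Compound 3 `CC(C)(O)C(=O)Nc1cc(Oc2ccc(Nc3nccc4[nH]cc(-c5ccc(F)cc5)c(=O)c34)cc2F)ccn1` gives -2.9% in this assay.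

Among these three, compound 3 stands second highest in this assay: compound 1 lies above it by a number 26.4 percentage points lower from compound 1 to compound 3 (beyond the scatter), and compound 2 lies below it by a number 39.3 percentage points higher from compound 2 to compound 3 (beyond the scatter). Both steps are beyond the scatter, so the group on the carbonyl carbon has mattered here, though not in one direction: a methyl added to the chain, a number 65.7 percentage points lower from compound 1 to compound 2 (beyond the scatter), gave the largest change of all.

Compound 4 `O=C(CO)Nc1cc(Oc2ccc(Nc3nccc4[nH]cc(-c5ccc(F)cc5)c(=O)c34)cc2F)ccn1` differs from compound 3 in one place: hydroxymethyl in place of 1-hydroxy-1-methylethyl on a carbonyl carbon. Within the data shown here, no measured step covers a hydroxymethyl on this carbonyl carbon. The closest comparisons, compound 1 to compound 3 and compound 2 to compound 3, show that small groups at this site have moved the read-out both ways by modest to large amounts, so no direction can be read from them. For compound 4 a step within the scatter, a number 7.9 percentage points higher from compound 3 to compound 4 (within the scatter), is therefore expected. Compound 4 is estimated at 5% in this assay, with a range from -30% to 35%.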

Compound 4, a percentage reported as inhibition, at one concentration (the size of the read-out at that concentration, not a potency): 18.5%
For compound 4 the middle estimate is 13.5 percentage points below the measured one; low and high end bracket the measured number.
By their numbers in this assay, from the lowest: compound 2; then compound 3; then compounds 4 and 1 (each within the scatter of the next).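

In this assay, hydroxymethyl in place of 1-hydroxy-1-methylethyl on the carbonyl carbon gives a number 21.4 percentage points higher from compound 3 to compound 4 (beyond the scatter), so a hydroxy group alone does not set the read-out here: what else the group carries also counts. Hydroxy in place of ethyl on the saturated chain carbon bound to the carbonyl carbon gives a number 5 percentage points lower from compound 1 to compound 4 (within the scatter), whereas hydroxy in place of propyl at that carbon gives a number 60.7 percentage points higher from compound 2 to compound 4 (beyond the scatter), which leaves the butyl of compound 2 as the group that stands furthest from the others. Nothing in the data shown accounts for these steps.

On these data alone, it remains open whether 1-hydroxyethyl, aminomethyl or a carboxylic acid on this carbonyl carbon would keep the read-out of compound 4. These single-concentration percentages also leave the potency of all four compounds unknown.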